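Chloro to Methyl on a Fused Aromatic Ring: Cytotoxicity

The source may hold more compounds than are shown below. What is called first, only, known or untested is meant among the compounds shown, and "the series" means these compounds.

Measured compounds:
- compound 1 `COc1ccc(N2CCN(CN3C(=O)/C(=N\NC(=S)NO)c4cc(F)ccc43)CC2)cc1` gives 260000 nM in an ADME assay on MT4 cells (Homo sapiens) for cytotoxicity, read by spectrophotometry, with a stated time of 5 days; on this read-out higher numbers stand for lower toxicity in this test and lower numbers for higher toxicity in this test
- compound 2 `CN(C)CN1C(=O)/C(=N\NC(=S)NO)c2cc(F)ccc21` gives 599000 nM in this assay
- compound 3 `CONC(=S)N/N=C1\C(=O)N(CN2CCN(c3c(F)cc4c(=O)c(C(=O)O)cn(C5CC5)c4c3OC)CC2C)c2ccc(Cl)cc21` gives 164000 nM in this assay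

Compound 3 has the lowest number of the three in this assay. Its gap to compound 1 lies within the scatter, so those two cannot be placed in an order; its gap to compound 2 lies beyond the scatter, so compound 2 shows clearly lower toxicity in this test than compound 3.

Compound 4 `CONC(=S)N/N=C1\C(=O)N(CN2CCN(c3c(F)cc4c(=O)c(C(=O)O)cn(C5CC5)c4c3OC)CC2C)c2ccc(C)cc21` differs from compound 3 in a single place: methyl in place of chloro on an aromatic carbon. The exchanged groups match in the counted atoms, donors, acceptors and charge, and only the halogen gives way to a carbon group. No measured pair here shows the effect of such a swap, so there is no shown step to lean on. Given the small size of the change, compound 4 is expected to sit close to compound 3, and the expected step of a 1.0-fold higher number from compound 3 to compound 4 (0.02 log units; within the scatter) is judged to fall within the scatter, in no clear direction. Compound 4 is thus estimated at 170000 nM, with a range from 80000 nM to 350000 nM.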

Compound 4, half-maximal cytotoxic concentration: 154000 nM
The estimate for compound 4 lay 1.1-fold (0.04 log units) above the measured number; the measured number falls inside the stated range.
By their numbers in this assay, from the lowest: compounds 4, 3 and 1 (each within the scatter of the next); then compound 2.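

In this assay, going by these compounds alone, putting methyl in place of chloro on this aromatic carbon gives a 1.1-fold lower number from compound 3 to compound 4 (0.03 log units; within the scatter) and is the first single-place change in this set, so it gives the first direct reading at this position. Within the scatter of this test, compound 3 and compound 4 cannot be told apart, which means that, for this pair, exchanging the halogen for a carbon group on the ring shows no measurable change in toxicity. Nothing available here explains why the two groups read alike.

As far as these compounds go, whether a group such as a nitrile, an amine or a longer chain like propyl at the same ring carbon would move the number clearly stays open. Also open, from the compounds shown here alone, is whether the same swap would read alike on a different side chain, since this single pair covers only one.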